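A few compounds are considered here, and "the series" means these few. Any claim that something is new, unique, unknown or untested is made for them only; others in the source may bear on it.

Measured so far:
Compound 1 `COc1cccc(C(=O)Oc2ccc3c(=O)c(-c4cc(OC)c(OC)cc4OC)coc3c2)c1`: > 10000 nM (a limit of the assay)
Compound 2 `COc1cc(OC)c(-c2coc3cc(OCc4cccc(F)c4)ccc3c2=O)cc1OC`: 1230 nM

Going by the values given here, in a functional assay on HepG2 cells (Homo sapiens) for antiproliferative activity, read by MTT assay, with a stated time of 24 h (a lower number here means a stronger inhibitor, a higher number a weaker inhibitor), compound 2 gives 1230 nM, the only actual number available. Compound 1 reaches only > 10000 nM, which is a limit and not a number, as the limit of > 10000 nM in this assay, at which 1 of the 2 values shown sits, records. Compound 2 therefore has a single measured neighbour, and that comparison is open-ended.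

Compound 3 `COc1cc(OC)c(-c2coc3cc(OCc4ccc(C(F)(F)F)cc4)ccc3c2=O)cc1OC` keeps the shared core and the saturated chain carbon bound to an oxygen on an aromatic ring, but carries 4-(trifluoromethyl)phenyl in place of 3-fluorophenyl on a saturated chain carbon bound to an oxygen on an aromatic ring. Among the compounds with values here, the only measured step, an at least 8.1-fold lower number from compound 1 to compound 2 (0.91 log units; beyond the scatter), acts at the same oxygen, but it replaces a (3-methoxyphenyl)carbonyl group with 3-fluorobenzyl. Within the data shown here, it says nothing direct about exchanging one benzyl group for another, and no measured pair tests such an exchange. No step beyond the scatter in this assay is therefore expected, and no direction is favoured, although the uncertainty is wide.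

The expected change is a 1.1-fold higher number from compound 2 to compound 3 (0.02 log units; within the scatter). For compound 3 the estimated value is 1300 nM, with an expected range from 350 nM to 5000 nM.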

Compound 3, half-maximal inhibitory concentration: 890 nM
Beside the measured number, compound 3's estimate is 1.5-fold (0.16 log units) above it; measured number inside the range.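

In this assay, the exchange of one benzyl group for another at this oxygen now has a direct reading, and it shows a 1.4-fold lower number from compound 2 to compound 3 (0.14 log units; within the scatter), so 4-(trifluoromethyl)phenyl and 3-fluorophenyl on this saturated chain carbon cannot be told apart here. The earlier gain from replacing the (3-methoxyphenyl)carbonyl group is also not confined to 3-fluorobenzyl, as a second benzyl group gives an at least 11-fold lower number from compound 1 to compound 3 (1.05 log units; beyond the scatter), which makes two compounds with a benzyl group on this oxygen against one with the carbonyl group. That step is open-ended, and its true size is unknown, as compound 1 is recorded only as a limit and not as a number: the limit of > 10000 nM in this assay, at which 1 of the 3 values shown sits.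

The step from 3-fluorophenyl to 4-(trifluoromethyl)phenyl changes both the substituent and its place on the ring, so the compounds shown cannot separate the two, and 3-(trifluoromethyl)benzyl or 4-fluorobenzyl would be needed to do so. As far as these compounds go, it also remains open whether the unsubstituted benzyl group, or a benzyl group carrying an amine or a carboxylic acid, would fall within the scatter of these two compounds or move the number beyond it.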